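Notes on the step from compound 3 to compound 4

The source may hold more compounds than are shown below. What is called first, only, known or untested is meant among the compounds shown, and "the series" means these compounds.

Measured compounds:
- compound 1 `COc1cc(C=C(C(=O)/C=C/c2cccc(OC)c2OC)C(=O)/C=C/c2cccc(OC)c2OC)ccc1O`: 200 nM
- compound 2 `COc1cccc(/C=C/C(=O)C(=Cc2cc(OC)c(OC)c(OC)c2)C(=O)/C=C/c2cccc(OC)c2OC)c1OC`: 220 nM
- compound 3 `COc1cc(OC)c(C=C(C(=O)/C=C/c2cccc(OC)c2OC)C(=O)/C=C/c2cccc(OC)c2OC)c(OC)c1`: 300 nM

In a functional assay on HepG2 cells (Homo sapiens) for antiproliferative activity, read by sulforhodamine B assay, with a stated time of 48 h (a lower number here means a stronger inhibitor, a higher number a weaker inhibitor), compound 3 gives 300 nM, which cannot be separated from the other two values: the data show a 1.4-fold higher number from compound 2 to compound 3 (0.13 log units; within the scatter) and a 1.5-fold higher number from compound 1 to compound 3 (0.18 log units; within the scatter), both within the scatter. The remaining step, a 1.1-fold higher number from compound 1 to compound 2 (0.04 log units; within the scatter), is also within the scatter.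

Next in the series is compound 4 `COc1cccc(/C=C/C(=O)C(=Cc2ccc(O)c(F)c2)C(=O)/C=C/c2cccc(OC)c2OC)c1OC`, with 3-fluoro-4-hydroxyphenyl in place of 2,4,6-trimethoxyphenyl on a double-bonded chain carbon bound to a double-bonded chain carbon. All three measured steps change this same place, so they bear directly on the new one. Among the measured compounds shown here, no compound measured so far carries fluorine, which leaves this an extrapolation. The nearest comparison is compound 1, whose 4-hydroxy-3-methoxyphenyl also holds a 4-hydroxy group, at 200 nM.

No change beyond the scatter is expected in this assay. The expected step is a 1.4-fold lower number from compound 3 to compound 4 (0.13 log units; within the scatter), which would remain within the scatter. For compound 4 the estimate is 220 nM, with an expected range of 100 nM to 500 nM.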

Compound 4, half-maximal inhibitory concentration: 220 nM
Beside the measured number, compound 4's estimate shows no gap at the digits printed; measured number inside the range.
By their numbers in this assay, from the lowest: compounds 1, 2, 4 and 3 (each within the scatter of the next).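

In this assay, the fluoro in place of methoxy on an aromatic carbon gives a 1.1-fold higher number from compound 1 to compound 4 (0.04 log units; within the scatter), so this position now also accepts a fluorine-bearing group without a separable shift. The entering 3-fluoro-4-hydroxyphenyl is smaller than 2,4,6-trimethoxyphenyl and adds a hydrogen-bond donor, yet that exchange gives a 1.4-fold lower number from compound 3 to compound 4 (0.13 log units; within the scatter), and the exchange for 3,4,5-trimethoxyphenyl gives no change at the digits printed from compound 2 to compound 4 (within the scatter), so all four groups at this place remain inseparable. Nothing available accounts for this level behaviour.

As far as these compounds go, whether the values stay level with an amine or a carboxylic acid on this phenyl group remains open. Also open, from the compounds shown here alone, is whether a fluoro group without the 4-hydroxy group, or a trifluoromethyl group in its place, would stay within the same narrow band.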